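Swapping Cyclopropyl for Methoxy in an EZH2 Series

A few compounds are considered here, and "the series" means these few. Any claim that something is new, unique, unknown or untested is made for them only; others in the source may bear on it.

Of the compounds shown here, three that share one core have been tested in an assay on isolated protein for inhibition of histone-lysine N-methyltransferase EZH2 (Homo sapiens), read by filter binding, with a stated time of 1 h; on this read-out higher numbers stand for weaker inhibition and lower numbers for stronger inhibition. Compound 1 `CSc1cc(C)n(C)c(=O)c1CN1CCc2c(Cl)cc(-c3c(C)noc3C)c(Cl)c2C1=O` gives 1.3 nM and compound 2 `Cc1cc(C)n(C)c(=O)c1CN1CCc2c(Cl)cc(-c3c(C)noc3C)c(Cl)c2C1=O` gives 14 nM, while compound 3 `Cc1noc(C)c1-c1cc(Cl)c2c(c1Cl)C(=O)N(Cc1c(C3CC3)cc(C)n(C)c1=O)CC2` gives 302 nM, the highest number of the three: the steps of a 22-fold higher number from compound 2 to compound 3 (1.33 log units; beyond the scatter) and a 230-fold higher number from compound 1 to compound 3 (2.37 log units; beyond the scatter) are both large. Compound 4 `COc1cc(C)n(C)c(=O)c1CN1CCc2c(Cl)cc(-c3c(C)noc3C)c(Cl)c2C1=O` differs from compound 3 by one change, (methoxy in place of cyclopropyl on an aromatic carbon). Since the methyl analogue (compound 2) and the methylsulfanyl analogue (compound 1) each sit far below compound 3, a small group at this carbon is expected to give a large drop again, with methoxy expected to land between those two. The expected step is a 38-fold lower number from compound 3 to compound 4 (1.58 log units; beyond the scatter). Compound 4 is therefore estimated at 8 nM, in the range 2 nM to 40 nM.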

Compound 4, half-maximal inhibitory concentration: 11.6 nM
Compound 4: middle estimate off by 1.5-fold (0.16 log units), on the low side; the range from low to high includes it.
By their numbers in this assay, from the lowest: compound 1; then compounds 4 and 2 (each within the scatter of the next); then compound 3.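

At this carbon, methoxy falls in with methyl rather than cyclopropyl: the data show a 26-fold lower number from compound 3 to compound 4 (1.42 log units; beyond the scatter) but only a 1.2-fold lower number from compound 2 to compound 4 (0.08 log units; within the scatter) and so methoxy and methyl cannot be told apart here. Methylsulfanyl keeps a clear lead over methoxy, with an 8.9-fold higher number from compound 1 to compound 4 (0.95 log units; beyond the scatter) as the step, so exchanging sulfur for oxygen in the group counts at this position. Nothing available explains these differences. From the compounds shown here alone, whether an ethoxy group, a longer chain or an amine at this carbon could match methylsulfanyl remains open.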